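Taking the chloro group off compound 2

A few compounds are considered here, and "the series" means these few. Any claim that something is new, unique, unknown or untested is made for them only; others in the source may bear on it.

Compound 1 `Cc1cc(OCc2cccc(C#N)c2)ccc1Cl`: 45000 nM
Compound 2 `COc1ccc(C(N)=O)cc1/C=C/c1ccc(Cl)cc1`: 7100 nM
Compound 3 `COc1ccc(C(N)=O)cc1/C=C\c1ccc(Cl)cc1`: 29000 nM

In an ADME assay on HCT-116 cells (Homo sapiens) for antiproliferative activity (a higher number here means a weaker inhibitor, a lower number a stronger inhibitor), compound 2 gives 7100 nM, the lowest of the three numbers, while compound 3 gives 29000 nM and compound 1 gives 45000 nM. Compound 4 `COc1ccc(C(N)=O)cc1/C=C/c1ccccc1` departs from compound 2 in one place: hydrogen in place of chloro on an aromatic carbon, para to a large group.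

The only measured step between two of these compounds is a 4.1-fold higher number from compound 2 to compound 3 (0.61 log units; beyond the scatter). It is modest and concerns (the fact that compounds 2 and 3 differ only in the configuration as drawn), so it offers a yardstick of size and no direct test of the chloro group. All three measured compounds carry that group, which leaves the direction tentative. A step similar in size to a 4.1-fold higher number from compound 2 to compound 3 (0.61 log units; beyond the scatter) is expected in this assay, towards a higher number, and a result within the scatter would not be surprising. The expected change is a 2.0-fold higher number from compound 2 to compound 4 (0.29 log units; within the scatter). For compound 4 the estimated value is 14000 nM, with an expected range from 5000 nM to 40000 nM.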

Compound 4, half-maximal inhibitory concentration: 36000 nM
For compound 4 the middle estimate is 2.6-fold (0.41 log units) below the measured one, and the stated range covers the measured number.
By their numbers in this assay, from the lowest: compound 2; then compounds 3, 4 and 1 (each within the scatter of the next).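

In this assay, the chloro group on the aromatic carbon, para to a large group, proves to count for something: a 5.1-fold higher number from compound 2 to compound 4 (0.71 log units; beyond the scatter), so with hydrogen in that place the compound is a weaker inhibitor, by a step beyond the scatter. Among the compounds shown here, this is the first direct reading of that group, as all the earlier compounds carried it and the only earlier step concerned the configuration of the double bond. Nothing available bears on what lies behind this step.

The compounds shown leave open whether a fluoro, bromo or methyl group in the same place would serve as chloro does. They also leave open whether the chloro group counts for as much with the Z double bond of compound 3.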